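Bromo for methyl on the acyl chain of compound 3

The source may report more compounds than this note shows. Statements on the series, on what has been measured and on what is new or still open speak of the compounds shown alone.

Of the compounds shown here, three sharing one core have been measured in a functional assay on KYSE-450 cells (Homo sapiens) for inhibition, read by MTT assay, with a stated time of 48 h; on this read-out higher numbers stand for weaker inhibition and lower numbers for stronger inhibition. Compound 1 `C/C=C/C=C/C(=O)N(Cc1ccc(OC)c(O)c1)c1cc(OC)c(OC)c(OC)c1` gives 180 nM. Compound 2 `CC/C=C/C(=O)N(Cc1ccc(OC)c(O)c1)c1cc(OC)c(OC)c(OC)c1` gives 72 nM. Compound 3 `CCC(=O)N(Cc1ccc(OC)c(O)c1)c1cc(OC)c(OC)c(OC)c1` gives 98 nM. Compound 3 sits close to both neighbours: a 1.8-fold lower number from compound 1 to compound 3 (0.26 log units; within the scatter) and a 1.4-fold higher number from compound 2 to compound 3 (0.13 log units; within the scatter), so the three numbers are not clearly separated apart from a 2.5-fold lower number from compound 1 to compound 2 (0.40 log units; beyond the scatter).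

Compound 4 `COc1ccc(CN(C(=O)CBr)c2cc(OC)c(OC)c(OC)c2)cc1O` differs from compound 3 at the acyl chain only: bromo in place of methyl on a saturated chain carbon bound to a carbonyl carbon. Among the compounds with values here, no measured step swaps methyl for bromo, so nothing here speaks directly to this change. Within the data shown here, the steps that do touch the acyl chain, from compound 1 to compound 3 and from compound 2 to compound 3, were both within the scatter, and that is the only guidance available.

Compound 4 is therefore expected to land near compound 3, with an expected step of a 1.0-fold higher number from compound 3 to compound 4 (0.01 log units; within the scatter) in this assay. Among the measured compounds shown here, the estimate for compound 4 is 100 nM, with a range from 30 nM to 400 nM, the range kept wide because no measured pair shows this kind of change.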

Compound 4, half-maximal inhibitory concentration: 120 nM
Compound 4: the middle estimate sits 1.2-fold (0.08 log units) below what was measured, and the stated range covers the measured number.
By their numbers in this assay, from the lowest: compounds 2, 3, 4 and 1 (each within the scatter of the next, the first and the last beyond it).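

In this assay, within the data shown here, the first direct look at bromo in place of methyl on this saturated chain carbon bound to a carbonyl carbon gives a small change (a 1.2-fold higher number from compound 3 to compound 4 (0.09 log units; within the scatter)), so this swap does not clearly shift the number. Bromomethyl also stays close to the two unsaturated chains (a 1.7-fold higher number from compound 2 to compound 4 (0.22 log units; within the scatter); a 1.5-fold lower number from compound 1 to compound 4 (0.18 log units; within the scatter)), which makes compound 4 a fourth acyl group that is not separated from its neighbours, although compound 1 and compound 2 remain apart. Nothing measured here explains why the swap changes so little.

On these data alone, it remains open whether chloro, an amine or a carboxylic acid on this carbon would also stay this close to compound 3. A longer saturated chain carrying bromo at its end is likewise untested among the compounds shown.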